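The compounds below may be only part of what the source reports. "The series", "measured", "known", "first", "only" and "open" are said of these compounds alone.

Measured in a functional assay on M21 cells (Homo sapiens) for antiproliferative activity, read by sulforhodamine B assay, with a stated time of 48 h; a lower number here means a stronger inhibitor, a higher number a weaker inhibitor:

- compound 1, `CCCCCC(=O)Nc1ccc(S(=O)(=O)Oc2ccccc2C(C)C)cc1`: compound 1 gives 6700 nM
- compound 2, `CC(C)c1ccccc1OS(=O)(=O)c1ccc(NC(=O)CCCCl)cc1`: compound 2 gives 5100 nM
- compound 3, `CCCCCNC(=O)Nc1ccc(S(=O)(=O)Oc2ccccc2C(C)C)cc1`: compound 3 gives 4600 nM

All three numbers lie close together. The move from compound 1 to compound 2 is chloro in place of ethyl on a saturated chain carbon, three bonds along the chain from a carbonyl carbon, and it made a 1.3-fold lower number from compound 1 to compound 2 (0.12 log units; within the scatter). Compound 3 carries a different core: it differs from compound 1 by pentylamino in place of pentyl on a carbonyl carbon, with a 1.5-fold lower number from compound 1 to compound 3 (0.16 log units; within the scatter). Between compound 2 and compound 3 the reading is a 1.1-fold lower number from compound 2 to compound 3 (0.04 log units; within the scatter).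

Compound 4, `CC(C)c1ccccc1OS(=O)(=O)c1ccc(NC(=O)NCCCCl)cc1`, is not yet measured in this assay. It differs from compound 3 by chloro in place of ethyl on a saturated chain carbon, three bonds along the chain from an amide-type nitrogen. Within the data shown here, this is the same kind of change as the one from compound 1 to compound 2, on the other core; the place is not word for word the same, since in compound 1 the carbon sits three bonds along the chain from a carbonyl carbon, whereas in compound 3 it sits three bonds along the chain from an amide-type nitrogen. The change occurs twice among the compounds shown.

The expectation for compound 4 rests on compound 1 and compound 2, where the same change gave a 1.3-fold lower number from compound 1 to compound 2 (0.12 log units; within the scatter), a step within the scatter; the same kind of step is expected from compound 3 to compound 4, namely a 1.2-fold lower number from compound 3 to compound 4 (0.09 log units; within the scatter). The estimate for compound 4 in this assay is therefore 3700 nM, expected to lie between 1800 nM and 7500 nM.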

Compound 4, half-maximal inhibitory concentration: 9300 nM
The estimate for compound 4 lay 2.5-fold (0.40 log units) below the measured number; measured number outside the range, above it.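

In this assay, chloro in place of ethyl on the saturated chain carbon, three bonds along the chain from an amide-type nitrogen, gives a 2.0-fold higher number from compound 3 to compound 4 (0.31 log units; beyond the scatter), a modest step, while the two further steps, a 1.8-fold higher number from compound 2 to compound 4 (0.26 log units; within the scatter) and a 1.4-fold higher number from compound 1 to compound 4 (0.14 log units; within the scatter), add no separation beyond the scatter. Set beside the earlier step on the core of compound 1, the new step does not establish a real difference between the two cores: the same change on two cores in this assay, a 1.3-fold lower number (0.12 log units; within the scatter) from compound 1 to compound 2 and a 2.0-fold higher number (0.31 log units; beyond the scatter) from compound 3 to compound 4, 2.7-fold (0.42 log units) apart, within the scatter of two such steps. Among these compounds, this pair of steps gives no firm ground for saying that the change behaves differently on the two cores, yet it does not show that the change carries over either, as each core offers only one such pair.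

The compounds shown leave open whether the modest step on the core of compound 3 would recur with a bromo or a hydroxyl in place of the chloro, or with a longer chain carrying the chloro. They also leave open whether an amine at that place would give a step clearly beyond the scatter on both cores.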